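The source may hold more compounds than are shown below. What is called first, only, known or untested is meant among the compounds shown, and "the series" means these compounds.

In an assay on membranes from brain for displacement of a labelled ligand from Sigma non-opioid intracellular receptor 1 (Cavia porcellus), read by scintillation counting, with a stated time of 90 min (on this read-out higher numbers stand for weaker inhibition and lower numbers for stronger inhibition), three compounds have been measured so far:

- compound 1, `COc1cccc(-n2cc(C(=O)NCCCCN3CCc4cc(OC)c(OC)cc4C3)nn2)c1`: 20200 nM
- compound 2, `COc1ccccc1Cn1cc(C(=O)NCCCCN2CCc3cc(OC)c(OC)cc3C2)nn1`: 20600 nM
- compound 3, `COc1cccc(-n2cc(C(=O)NCCN3CCc4cc(OC)c(OC)cc4C3)nn2)c1`: 76700 nM

Compound 1 and compound 2 share a core and differ in one place, (2-methoxybenzyl in place of 3-methoxyphenyl on an aromatic nitrogen). This change made a step of a 1.0-fold higher number from compound 1 to compound 2 (0.01 log units; within the scatter), so the two compounds are indistinguishable within the usual scatter of this assay. Compound 3 carries a shorter chain between the amide and the ring-bound nitrogen than compound 1 does; the difference between the two cores is not broken down here. What the values show is that compound 3 gives a clearly higher number than either compound 1 or compound 2, meaning weaker inhibition.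

Compound 4, `COc1ccccc1Cn1cc(C(=O)NCCN2CCc3cc(OC)c(OC)cc3C2)nn1`, has not yet been measured. It relates to compound 3 in the same way that compound 2 relates to compound 1: 2-methoxybenzyl in place of 3-methoxyphenyl on an aromatic nitrogen. The surroundings of the change are the same in both pairs. This is the same change, seen for the second time.

The expectation rests on one observation only: when this change was made from compound 1 to compound 2 it produced a step of a 1.0-fold higher number from compound 1 to compound 2 (0.01 log units; within the scatter). The step from compound 3 to compound 4 is therefore expected to be of a similar size, a 1.0-fold higher number from compound 3 to compound 4 (0.01 log units; within the scatter), keeping compound 4 near compound 3. Compound 4 is estimated to give 78000 nM in this assay, with the likely range spanning 30000 nM to 200000 nM.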

Compound 4, inhibition constant: 18600 nM
Compound 4: the middle estimate sits 4.2-fold (0.62 log units) above what was measured; the measured number lies below the stated range.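

In this assay, putting 2-methoxybenzyl in place of 3-methoxyphenyl on the aromatic nitrogen gave a 4.1-fold lower number from compound 3 to compound 4 (0.62 log units; beyond the scatter), so the change did not carry over from one core to the other with the same effect: the same change on two cores in this assay, a 1.0-fold higher number (0.01 log units; within the scatter) from compound 1 to compound 2 and a 4.1-fold lower number (0.62 log units; beyond the scatter) from compound 3 to compound 4, 4.2-fold (0.62 log units) apart, beyond the scatter of two such steps. Lower numbers here mean stronger inhibition, so the same swap made no discernible difference on the core of compound 1 but gave stronger inhibition on the core of compound 3, which carries the shorter chain between the amide and the ring-bound nitrogen. This shows that, for these two pairs, the outcome of the change depends on the core that carries it, but two pairs cannot give a rule for the series, and the numbers alone do not show why the two steps differ.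

The compounds shown leave open whether the gain on the shorter-chain core would also appear with a plain benzyl group, which has no methoxy group, and so which part of the 2-methoxybenzyl group goes with it. They also leave open how the same swap would behave on a core with a chain of intermediate length, or with a chain longer than any shown here.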